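Second Chloro on the Fused Ring: Expected Loss of Potency

This account rests on a few compounds, and the source may have more. Where it says the series, first, only, none or still open, it means among the compounds named here.

Measured compounds:
- compound 1, `COc1ccccc1N1CCN(C(=O)CCc2c(-c3ccc(Cl)cc3)[nH]c3ccccc23)CC1`; in an assay on CHO cells for displacement of a labelled ligand from Substance-P receptor (Homo sapiens) (on this read-out lower numbers stand for stronger inhibition and higher numbers for weaker inhibition), compound 1 gives 31 nM
- compound 2, `COc1ccccc1N1CCN(C(=O)CCc2c(-c3ccc(Cl)cc3)[nH]c3cccc(Cl)c23)CC1`; in this assay compound 2 gives 950 nM
- compound 3, `COc1ccccc1N1CCN(C(=O)CCc2c(-c3ccc(Cl)cc3)[nH]c3cc(Cl)ccc23)CC1`; in this assay compound 3 gives 4.9 nM
- compound 4, `COc1ccccc1N1CCN(C(=O)CCc2c(-c3ccc(Cl)cc3)[nH]c3cc(Cl)cc(Cl)c23)CC1`; not yet measured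

Compound 3 has the lowest number of the three, so it is the strongest binder in this set. Its nearest neighbour is compound 1, and the step of a 6.3-fold lower number from compound 1 to compound 3 (0.80 log units; beyond the scatter) is beyond the scatter. Its furthest neighbour is compound 2, and the step of a 31-fold higher number from compound 1 to compound 2 (1.49 log units; beyond the scatter) is also beyond the scatter, in the opposite direction.

Compound 4 differs from compound 3 by chloro in place of hydrogen on an aromatic carbon. Among the compounds with values here, this is the same kind of change, at the same place on the shared core, as the one that turned compound 1 into compound 2, where the number rose sharply. Compound 3 already carries the chloro that helped in going from compound 1 to compound 3, so compound 4 combines the helpful and the harmful substitution. The step from compound 1 to compound 2 is the one that bears directly on this change, and it was large. A large rise in the number is therefore expected, a 27-fold higher number from compound 3 to compound 4 (1.42 log units; beyond the scatter), in this assay. For compound 4 the estimate in this assay is 130 nM, with a range from 30 nM to 600 nM.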

Compound 4, half-maximal inhibitory concentration: 570 nM
Compound 4: middle estimate off by 4.4-fold (0.64 log units), on the low side; measured number inside the range.
By their numbers in this assay, from the lowest: compound 3; then compound 1; then compounds 4 and 2 (each within the scatter of the next).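

In this assay, a chloro ortho to a fused ring raises the number on both cores, but not by a fixed amount: on the core that already carries a chloro meta to this position, the result is a 120-fold higher number from compound 3 to compound 4 (2.07 log units; beyond the scatter). The two chloro groups therefore do not simply add up, and the harm from this position is larger when the other chloro is present: the same change on two cores in this assay, a 31-fold higher number (1.49 log units; beyond the scatter) from compound 1 to compound 2 and a 120-fold higher number (2.07 log units; beyond the scatter) from compound 3 to compound 4, 3.8-fold (0.58 log units) apart, beyond the scatter of two such steps. Seen from the other side, the help from the second chloro fades once this position is filled, leaving only a 1.7-fold lower number from compound 2 to compound 4 (0.22 log units; within the scatter), so with this position occupied that chloro no longer separates the two compounds beyond the scatter: the same change on two cores in this assay, a 6.3-fold lower number (0.80 log units; beyond the scatter) from compound 1 to compound 3 and a 1.7-fold lower number (0.22 log units; within the scatter) from compound 2 to compound 4, 3.8-fold (0.58 log units) apart, beyond the scatter of two such steps.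

The compounds shown cannot tell whether the loss belongs to chloro itself or to any group at this position, and a fluoro, a methyl or a methoxy here would begin to separate those cases. On these data alone, it also remains open whether the same interplay between the two positions would hold with fluoro in place of the other chloro, or with a longer chain in place of the one that joins the shared core to the amide carbonyl.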